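The source may report more compounds than this note shows. Statements on the series, on what has been measured and on what is new or still open speak of the compounds shown alone.

Measured so far in an assay on SHEP1 cells for agonist activity at Neuronal acetylcholine receptor; alpha4/beta2 (Homo sapiens), read by FLIPR and calcium flux; on this read-out lower numbers stand for smaller maximal responses and higher numbers for larger maximal responses:

Compound 1, `C[C@H]1C[C@H]1C(=O)N1CC2CNCC2C1`: 100%
Compound 2, `C[C@@H]1C[C@H]1C(=O)N1CC2CNCC2C1`: 100%
Compound 3, `CC(=O)N1CC2CNCC2C1`: 110%

Compound 3 sits at the top of these three numbers, yet only by a number 10 percentage points higher from compound 1 to compound 3 (within the scatter) and a number 10 percentage points higher from compound 2 to compound 3 (within the scatter), each within the scatter, so the three compounds cannot be told apart on this read-out. The pair of compound 1 and compound 2 differ only in how a ring stereocentre is drawn, and there too the result is no change at the digits printed from compound 1 to compound 2 (within the scatter); the note the fact that one of compounds 1 and 2 is drawn with a defined configuration and the other without, at the place where they differ belongs to that pair.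

Compound 4 is `CCC(=O)N1CC2CNCC2C1`. It differs from compound 3 by methyl in place of hydrogen on a saturated chain carbon bound to a carbonyl carbon. The two steps that bear on it are those from the 2-methylcyclopropyl compounds to the methyl compound, both small and within the scatter; swapping the whole 2-methylcyclopropyl for methyl moved nothing beyond the usual spread. A further single methyl on the saturated chain carbon is a smaller change than that, so in this assay no step beyond the scatter is expected, and a number 5 percentage points lower from compound 3 to compound 4 (within the scatter) is the estimated step.

Compound 4 is therefore expected to give 105% in this assay, with a range from 90% to 120%.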

Compound 4, largest response reached (Emax), in percent of the reference or control that the assay uses: 120%
Compound 4: middle estimate off by 15 percentage points, on the low side; low and high end bracket the measured number.
By their numbers in this assay, from the lowest: compounds 1, 2, 3 and 4 (each within the scatter of the next, the first and the last beyond it).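

In this assay, going by these compounds alone, the swap of 2-methylcyclopropyl for ethyl on the carbonyl carbon is the only change so far to leave the scatter, giving a number 20 percentage points higher from compound 1 to compound 4 (beyond the scatter) and a number 20 percentage points higher from compound 2 to compound 4 (beyond the scatter) as the two steps. The single methyl added to the saturated chain carbon gives a number 10 percentage points higher from compound 3 to compound 4 (within the scatter) on its own, so acetyl and propanoyl cannot be told apart here, although the ethyl compound can be told from the 2-methylcyclopropyl compounds while the methyl compound cannot. Nothing at hand explains these steps.

Going by these compounds, whether a longer chain such as propyl or butyl, a branched group such as isopropyl, or an amine on this chain carbon would hold the response at this level remains open. Also open, on these data alone, is how much of each compound is needed to reach its largest response.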